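Methoxycarbonyl in place of methylcyclopropyl carbonyl on the shared core

The source may report more compounds than this note shows. Statements on the series, on what has been measured and on what is new or still open speak of the compounds shown alone.

Measured compounds and their values in an assay on CHO cells for displacement of a labelled ligand from Neuronal acetylcholine receptor; alpha3/beta4 (Homo sapiens), read by scintillation counting, with a stated time of 2 h; a lower number here means a stronger inhibitor, a higher number a weaker inhibitor:
compound 1 `C[C@H]1C[C@H]1C(=O)N1CC2CNCC2C1`: 2000 nM
compound 2 `C[C@@H]1C[C@@H]1C(=O)N1CC2CNCC2C1`: 280 nM
compound 3 `C[C@H]1C[C@@H]1C(=O)N1CC2CNCC2C1`: 13000 nM

Compound 2 gives the lowest number of the three; the nearest step to it is a 7.1-fold lower number from compound 1 to compound 2 (0.85 log units; beyond the scatter), and the furthest is a 46-fold higher number from compound 2 to compound 3 (1.67 log units; beyond the scatter). The three measured steps all concern stereocentres on the same atoms and bonds the fact that one of compounds 1 and 2 is drawn with a defined configuration and the other without, at the place where they differ the fact that one of compounds 1 and 3 is drawn with a defined configuration and the other without, at the place where they differ (the fact that one of compounds 2 and 3 is drawn with a defined configuration and the other without, at the place where they differ). Compound 4 `COC(=O)N1CC2CNCC2C1` differs from compound 2 by a group of 2 heavy atoms (1 carbon, 1 oxygen; no ring) in place of a group of 4 heavy atoms (4 carbon; one three-membered non-aromatic ring of carbon only), on a carbonyl carbon, a methoxy entering in place of a methyl-bearing three-membered ring. Among the compounds with values here, no measured step bears on such a change, so no direction can be taken from them. The account expects a weaker binder than compound 2, with a step of an 11-fold higher number from compound 2 to compound 4 (1.03 log units; beyond the scatter), and estimates compound 4 at 3000 nM, ranging from 500 nM to 20000 nM.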

Compound 4, inhibition constant: 14000 nM
For compound 4 the middle estimate is 4.7-fold (0.67 log units) below the measured one; low and high end bracket the measured number.
By their numbers in this assay, from the lowest: compound 2; then compound 1; then compounds 3 and 4 (each within the scatter of the next).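

At this carbonyl carbon, methoxy gives a much weaker binder than the most potent 2-methylcyclopropyl isomer (a 50-fold higher number from compound 2 to compound 4 (1.70 log units; beyond the scatter)), and a smaller step runs the same way from another isomer (a 7.0-fold higher number from compound 1 to compound 4 (0.85 log units; beyond the scatter)). The third step stays within the scatter (a 1.1-fold higher number from compound 3 to compound 4 (0.03 log units; within the scatter)), so the cost of methoxy depends on which stereoisomer it replaces. Nothing at hand accounts for these steps. On these data alone, whether they follow from losing the ring or from gaining the oxygen stays open, and so does the reading of an ethoxy or unsubstituted cyclopropyl group on this carbonyl carbon.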